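The source may hold more compounds than are shown below. What is called first, only, known or untested is meant among the compounds shown, and "the series" means these compounds.

Compound 1 `Cc1nnc(SCc2cc(=O)c3ccccc3o2)s1` was tested in a functional assay on LM7 cells (Homo sapiens) for cytotoxicity, read by MTT assay, with a stated time of 72 h (on this read-out higher numbers stand for weaker inhibition and lower numbers for stronger inhibition), and in that assay compound 1 gives > 25000 nM, which is a limit of the assay rather than a number. Compound 2 `Cc1cc(C)nc(SCc2cc(=O)c3ccccc3o2)n1` gives > 25000 nM in this assay, again a limit. Compound 3 `Cc1ccc2oc(CSc3nc(C)cc(C)n3)cc(=O)c2c1` gives > 25000 nM in this assay, also a limit. The change methyl in place of hydrogen on an aromatic carbon therefore makes a step that the two limits leave unreadable from compound 2 to compound 3, because of the limit of > 25000 nM in this assay, at which 3 of the 3 values shown sit. How the core of compound 1 and the core of compound 2 differ is not broken down here. Compound 4 `Cc1ccc2oc(CSc3nnc(C)s3)cc(=O)c2c1` carries the same change, (methyl in place of hydrogen on an aromatic carbon), and is not yet measured in this assay. Since compound 1 sits at > 25000 nM and the same change left compound 3 at a limit, compound 4 is expected to show a step that the limit leaves unreadable from compound 1 to compound 4. Compound 4 is estimated at 30000 nM in this assay.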

Compound 4, half-maximal inhibitory concentration: > 25000 nM
Compound 4: only a limit was reported; the forecaster's own chance of this, stated with the estimate: 85%; the middle value does not contradict the limit.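

No size can be read for the step from compound 1 to compound 4, because both values are limits: the limit of > 25000 nM in this assay, at which 4 of the 4 values shown sit. The compounds shown leave open what actual value any of them has in this assay and whether the methyl changes it at all.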